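A few compounds are considered here, and "the series" means these few. Any claim that something is new, unique, unknown or untested is made for them only; others in the source may bear on it.

Compound 1 `CC(=O)N1N=C(c2ccc3ccccc3c2)OC1c1ccccc1` gives 2.11 ug/mL
Compound 2 `CC(=O)N1N=C(c2ccc3ccccc3c2)OC1c1ccccc1F` gives 3.36 ug/mL
Compound 3 `CC(=O)N1N=C(c2ccc3ccccc3c2)OC1c1ccsc1` gives 6.82 ug/mL

Within the data shown here, in a functional assay on HepG2 cells (Homo sapiens) for antiproliferative activity, read by MTT assay, with a stated time of 48 h (on this read-out lower numbers stand for stronger inhibition and higher numbers for weaker inhibition), compound 1 stands at 2.11 ug/mL and no measured compound lies clearly below it. Its nearest neighbour sits within the scatter (a 1.6-fold higher number from compound 1 to compound 2 (0.20 log units; within the scatter)) and its furthest beyond it (a 3.2-fold higher number from compound 1 to compound 3 (0.51 log units; beyond the scatter)). Compound 4 `CC(=O)N1N=C(c2ccc3ccccc3c2)OC1c1ccc(OCc2ccccc2)cc1` carries a single change from compound 1 (benzyloxy in place of hydrogen on an aromatic carbon): benzyloxy in place of hydrogen on an aromatic carbon, para to a large group. Neither measured step matches this closely. Both point, at most, to a modest upward move in this assay, and the expected step is a 1.9-fold higher number from compound 1 to compound 4 (0.28 log units; within the scatter) with wide uncertainty. Compound 4 is estimated at 4 ug/mL within a range of 1.5 ug/mL to 11 ug/mL as expected bounds.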

Compound 4, half-maximal inhibitory concentration: 3.38 ug/mL
Beside the measured number, compound 4's estimate is 1.2-fold (0.07 log units) above it, within the range that was stated.
By their numbers in this assay, from the lowest: compounds 1, 2, 4 and 3 (each within the scatter of the next, the first and the last beyond it).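

The earlier compounds shown here changed this ring only through a fluoro group or its replacement by thiophen-3-yl. Compound 4 shows that in this assay a much larger benzyloxy group, on an aromatic carbon, para to a large group, gives a 1.6-fold higher number from compound 1 to compound 4 (0.20 log units; within the scatter), so this place accepts that group without a shift beyond the scatter. Nothing available explains this result. Open, going by these compounds, is whether a methoxy group, an amine or a carboxylic acid at the same place would behave alike, and whether the oxygen or the added benzene ring matters more.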